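A few compounds are considered here, and "the series" means these few. Any claim that something is new, unique, unknown or untested is made for them only; others in the source may bear on it.

Of the compounds shown here, three built on one shared core have been tested in a functional assay on the whole organism (strain Wistar) for inhibition, with Rattus norvegicus as the target, read by paw edema, with a stated time of 4 h, at a dose of 10 mg/kg by the oral route; on this read-out lower numbers stand for less inhibition and higher numbers for more inhibition at the one dose given (going by the name of the read-out). Compound 1 `CCCCNc1nnc(COc2ccc(-c3ccccc3)cc2)s1` carries a butyl group on a nitrogen on an aromatic ring and gives 27.3%. Compound 2 `Brc1ccc(Nc2nnc(COc3ccc(-c4ccccc4)cc3)s2)cc1`, with 4-bromophenyl on that nitrogen instead, gives 63.6%, and compound 3 `Fc1ccc(Nc2nnc(COc3ccc(-c4ccccc4)cc3)s2)cc1`, with 4-fluorophenyl there, gives 29.5%. On these numbers compound 3 cannot be told apart from compound 1, and both lie well under compound 2.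

Compound 4 `Cc1ccccc1Nc1nnc(COc2ccc(-c3ccccc3)cc2)s1` is the next step from compound 3: 2-methylphenyl in place of 4-fluorophenyl on a nitrogen on an aromatic ring. Two earlier steps bear on this. The step of a number 2.2 percentage points higher from compound 1 to compound 3 (within the scatter) shows that putting 4-fluorophenyl in place of butyl changed little, whereas a number 34.1 percentage points lower from compound 2 to compound 3 (beyond the scatter) and a number 36.3 percentage points higher from compound 1 to compound 2 (beyond the scatter) show that what sits on the phenyl can shift the read-out a great deal. Among the compounds with values here, no measured step covers a methyl group, nor a 2-substituted phenyl, so the direction for compound 4 is open. The one firm point is that aryl groups on this nitrogen have ranged from about the level of compound 3 up to that of compound 2. Compound 4 is therefore expected to give 40%, within 20% to 65%, an estimated step of a number 10.5 percentage points higher from compound 3 to compound 4 (beyond the scatter) that could well fall within the scatter.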

Compound 4, a percentage reported as inhibition, in the whole organism at one dose (the size of the read-out at that dose, not a potency): 29.5%
Estimate against measurement, compound 4: 10.5 percentage points above; measured number inside the range.
By their numbers in this assay, from the lowest: compounds 1, 3 and 4 (each within the scatter of the next); then compound 2.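

Placing 2-methylphenyl instead of 4-fluorophenyl on this nitrogen gives no change at the digits printed from compound 3 to compound 4 (within the scatter), and placing it instead of butyl gives a number 2.2 percentage points higher from compound 1 to compound 4 (within the scatter), so a second aryl group with a different substituent also stays level with the butyl compound. The gap to the bromo compound stands as well, at a number 34.1 percentage points lower from compound 2 to compound 4 (beyond the scatter): of the three aryl groups shown here, only 4-bromophenyl stands apart, and compounds 3 and 4 go against any idea that an aryl group on this nitrogen raises the number by itself. Nothing available explains why 4-bromophenyl behaves differently from 4-fluorophenyl and 2-methylphenyl.

Going by these compounds, it remains open whether the high number of compound 2 depends on bromo itself, on its place at position 4 of the phenyl ring, or on both, and 4-chlorophenyl, 4-methylphenyl, 2-bromophenyl and plain phenyl would help to separate these readings. Each number also comes from a single dose, so these compounds leave open how the groups would compare at other doses.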